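The compounds below may be only part of what the source reports. "The series", "measured", "known", "first", "only" and "open" are said of these compounds alone.

Compound 1 `Nc1nc(Cl)c2ncn(Cc3ccc(CCl)cc3)c2n1`: 46800 nM
Compound 2 `ClCc1cccc(Cn2cnc3c(Cl)nc(Cl)nc32)c1`: 8920 nM
Compound 3 `ClCc1ccc(Cn2cnc3c(Cl)nc(Cl)nc32)cc1`: this value is a limit of the assay, > 100000 nM

All three were tested in a functional assay on SNB-19 cells (Homo sapiens) for cytotoxicity, read by sulforhodamine B assay, with a stated time of 48 h; a lower number here means that less compound is tolerated, a higher number that more compound is tolerated. Among the two plain numbers, compound 2 gives the lowest, and compound 1 sits an at least 2.1-fold lower number from compound 3 to compound 1 (0.32 log units; beyond the scatter)-sized step away from compound 3; that step is the only measured example of the change (amino in place of chloro on an aromatic carbon). Its size is itself only a bound, because compound 3 sits at the limit of > 100000 nM in this assay, at which 1 of the 3 values shown sits.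

Compound 4 `Nc1nc(Cl)c2ncn(Cc3cccc(CCl)c3)c2n1` is the compound in which the same change, (amino in place of chloro on an aromatic carbon), is made on the core of compound 2. The surroundings of the changed carbon are the same word for word in both cases. How the core of compound 2 differs from that of compound 3 is not broken down here: the two contain the same atoms joined differently.

The step from compound 2 to compound 4 is expected to be a 2.2-fold lower number from compound 2 to compound 4 (0.35 log units; beyond the scatter), because the measured step of an at least 2.1-fold lower number from compound 3 to compound 1 (0.32 log units; beyond the scatter) made the number lower. Compound 4 is therefore estimated at 4000 nM in this assay, within a range of 1500 nM to 12000 nM.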

Compound 4, concentration lethal to 50% of the cells: 46800 nM
Beside the measured number, compound 4's estimate is 12-fold (1.07 log units) below it, and the stated range ends below it.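

In this assay, among the compounds shown here, putting amino in place of chloro gives a 5.2-fold higher number from compound 2 to compound 4 (0.72 log units; beyond the scatter), so this change cannot simply be carried from one core to the other, as the two measured steps run in opposite directions and differ by more than the scatter: the same change on two cores in this assay, an at least 2.1-fold lower number (0.32 log units; beyond the scatter) from compound 3 to compound 1 and a 5.2-fold higher number (0.72 log units; beyond the scatter) from compound 2 to compound 4, at least 11-fold (1.04 log units) apart, beyond the scatter of two such steps Compound 3 carries a limit of the assay rather than a plain number, so the earlier step is only a bound and its true size remains unknown: the limit of > 100000 nM in this assay, at which 1 of the 4 values shown sits. With only two pairs of compounds, the result does not show why the cores respond differently, or which way the same change would go on any further core.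

The compounds shown leave open whether a different group on the same aromatic carbon, such as a methoxy group or a methylamine, would behave like amino on either core. They also leave open whether the reversal would persist if the chloro group that stays on that ring were replaced by a methyl group.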